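The source may hold more compounds than are shown below. What is called first, only, known or untested is meant among the compounds shown, and "the series" means these compounds.

Working notes on the series in a functional assay on A549 cells (Homo sapiens) for inhibition, read by colorimetric assay and MTT assay, with a stated time of 72 h; on this read-out higher numbers stand for weaker inhibition and lower numbers for stronger inhibition. Compound 1 `C=CCCCCCOc1ncc(-c2ccccc2OCCCCC=C)n1C` gives 62000 nM. Compound 2 `COc1ccccc1-c1cnc(OC)n1C` reads > 100000 nM, which is a limit of the assay and not a number. Compound 3 `C=CCCCCOc1ccccc1-c1cnc(OC)n1C` gives 80000 nM. Among the measured compounds shown here, it stands with the only other true number in the set, at a 1.3-fold higher number from compound 1 to compound 3 (0.11 log units; within the scatter).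

Compound 4 `C=CCCCCOc1ccccc1-c1cnc(NC(=O)CCCC=C)n1C` carries ((pent-4-en-1-yl)carbonyl)amino in place of methoxy on an aromatic carbon, between two ring nitrogen atoms: ((pent-4-en-1-yl)carbonyl)amino in place of methoxy on an aromatic carbon.

For the measured compounds named here, two measured steps bear on this. The closer one changes the chain on the oxygen at that same aromatic carbon, and compound 1 and compound 3 show a 1.3-fold higher number from compound 1 to compound 3 (0.11 log units; within the scatter). The other changes the chain on the oxygen at the second aromatic ring, giving an at least 1.2-fold lower number from compound 2 to compound 3 (0.09 log units; that floor lies within the scatter), and it starts from the limit noted for compound 2: the limit of > 100000 nM in this assay, at which 1 of the 3 values shown sits. Going by the values given here, no measured compound has an amide link at this carbon, so the evidence is indirect and the range must stay wide.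

With both steps this small, no shift beyond the scatter is expected in this assay. The estimated step is a 1.6-fold lower number from compound 3 to compound 4 (0.20 log units; within the scatter). For compound 4 the expected value is 50000 nM, with an estimated range from 14000 nM to 100000 nM.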

Compound 4, half-maximal inhibitory concentration: 8000 nM
Compound 4: the middle estimate sits 6.3-fold (0.80 log units) above what was measured; the measured number lies below the stated range.
By their numbers in this assay, from the lowest: compound 4; then compounds 1 and 3 (each within the scatter of the next). At a limit, above all of these: compound 2.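

In this assay, the aromatic carbon between two ring nitrogen atoms now responds beyond the scatter: ((pent-4-en-1-yl)carbonyl)amino in place of methoxy gives a 10-fold lower number from compound 3 to compound 4 (1.00 log units; beyond the scatter), and the same group in place of (hept-6-en-1-yl)oxy gives a 7.8-fold lower number from compound 1 to compound 4 (0.89 log units; beyond the scatter). Changing only the chain on the oxygen at this carbon gave no such separation, with a 1.3-fold higher number from compound 1 to compound 3 (0.11 log units; within the scatter), so in these compounds the shift appears only when the amide link enters, from either oxygen-linked group. No measured property at hand accounts for this step, and the cause stays unassigned.

From the compounds shown here alone, it remains open which part of the new group carries the step: an acetylamino group, a plain amine or a saturated hexanoylamino chain at this carbon would separate the amide link from the chain and its terminal double bond. Going by these compounds, it is also open whether the hex-5-en-1-yl chain on the oxygen at the second aromatic ring contributes once the amide is in place, as a methoxy group there alongside the amide would show.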